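Carbonate in place of methyl on the pyrrolidine side chain

The source may report more compounds than this note shows. Statements on the series, on what has been measured and on what is new or still open speak of the compounds shown alone.

Compound 1, `COC[C@H]1C[C@@](CC(C)C)(C(=O)O)N(C(=O)c2ccc(C(C)(C)C)c(OC)c2)[C@H]1COC`: > 120000 nM
Compound 2, `CC[C@H]1[C@@H](COC)C[C@@](CC(C)C)(C(=O)O)N1C(=O)c1ccc(C(C)(C)C)c(OC)c1`: 200000 nM

In an ADME assay on Huh-5-2 cells (Homo sapiens) for cytotoxicity, with a stated time of 3 days (on this read-out higher numbers stand for lower toxicity in this test and lower numbers for higher toxicity in this test), compound 1 gives > 120000 nM, which is a limit of the assay and not a number. Within the data shown here, compound 2 gives 200000 nM in this assay, the only value that is a number rather than a limit. Among the measured compounds shown here, the one measured step, a step that the limit leaves unreadable from compound 1 to compound 2, cannot be read because of the limit of > 120000 nM in this assay, at which 1 of the 2 values shown sits, so it gives no usable size for the effect of changing the chain on the saturated ring carbon.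

Compound 3, `COC[C@H]1C[C@@](CC(C)C)(C(=O)O)N(C(=O)c2ccc(C(C)(C)C)c(OC)c2)[C@H]1COC(=O)OC`, differs from compound 2 by (methoxycarbonyl)oxy in place of methyl on a saturated chain carbon bound to a saturated ring carbon. For the measured compounds named here, no measured step bears on this change; the measured step that the limit leaves unreadable from compound 1 to compound 2 concerns a different exchange and is itself unreadable. With nothing to point either way, and with compound 2 already weakly toxic, a step in this assay beyond the scatter is not expected in either direction. Compound 3 is therefore expected to give about 150000 nM in this assay, within 50000 nM to 400000 nM, which means an expected step of a 1.3-fold lower number from compound 2 to compound 3 (0.12 log units; within the scatter).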

Compound 3, half-maximal cytotoxic concentration: > 120000 nM
Compound 3 gave a limit, no number; the forecaster's own chance of this, stated with the estimate: 50%; the middle value does not contradict the limit.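

In this assay compound 3 gives > 120000 nM, which is a limit of the assay and not a number. The steps joining compound 3 to compound 1 and compound 2 therefore cannot be read, because of: the limit of > 120000 nM in this assay, at which 2 of the 3 values shown sit.

On these data alone, whether (methoxycarbonyl)oxy in place of methyl changes the half-maximal cytotoxic concentration at all stays open.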